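Methylating the ring amide nitrogen of compound 2

A few compounds are considered here, and "the series" means these few. Any claim that something is new, unique, unknown or untested is made for them only; others in the source may bear on it.

Measured so far:
compound 1 `CCOC(=O)/C=C1/C(=O)Nc2ccccc21`: 77.7%
compound 2 `CC(C)(C)OC(=O)/C=C1/C(=O)Nc2ccccc21`: 94.5%

In a functional assay on HL-60 cells (Homo sapiens) for inhibition, read by CCK-8 assay, with a stated time of 72 h, tested at 20 uM (a higher number here means more inhibition of growth at the concentration tested, a lower number less inhibition of growth), compound 2 gives the higher of the two numbers; the step of a number 16.8 percentage points higher from compound 1 to compound 2 (beyond the scatter) came with tert-butyl in place of ethyl on an oxygen next to a carbonyl group. Compound 3 `CN1C(=O)/C(=C/C(=O)OC(C)(C)C)c2ccccc21` differs from compound 2 by methyl in place of hydrogen on an amide-type nitrogen in a ring. Among the measured compounds shown here, no measured step touches the amide-type nitrogen, so that single step to compound 2 gives no guidance here, and nothing points to a direction. Compound 3 is therefore estimated at 85% in this assay, within 50% to 98%, meaning an expected step of a number 9.5 percentage points lower from compound 2 to compound 3 (within the scatter) that need not exceed the scatter.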

Compound 3, percent growth inhibition at one concentration: 94.7%
Estimate against measurement, compound 3: 9.7 percentage points below, within the range that was stated.
By their numbers in this assay, from the lowest: compound 1; then compounds 2 and 3 (each within the scatter of the next).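

Methyl in place of hydrogen on the amide-type nitrogen gives a number 0.2 percentage points higher from compound 2 to compound 3 (within the scatter) in this assay and so offers the first reading at this position. With tert-butyl on the ester oxygen, the amide hydrogen can therefore be replaced by methyl without a change beyond the scatter in this growth read-out. Nothing measured here explains this result.

From the compounds shown here alone, whether an ethyl group, a longer chain or a chain carrying an amine would fare the same on this nitrogen stays open. So does whether methyl there behaves alike in compound 1, with its ethyl ester.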